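Series notes: removing the ring methyl of compound 2

The source may report more compounds than this note shows. Statements on the series, on what has been measured and on what is new or still open speak of the compounds shown alone.

Measured so far:
compound 1 `Cc1ccc2c(=O)c(CSC(=S)N3CCOCC3)coc2c1`: 14300 nM in a functional assay on LM7 cells (Homo sapiens) for antiproliferative activity, read by MTT assay, with a stated time of 72 h; a lower number here means a stronger inhibitor, a higher number a weaker inhibitor
compound 2 `Cc1ccc2c(=O)c(CSC(=S)N3CCCC3)coc2c1`: 3400 nM in this assay
compound 3 `Cc1ccc2c(=O)c(CSC(=S)N3CCCCC3)coc2c1`: 5100 nM in this assay

Compound 2 holds the lowest of the three numbers in this assay. The steps of a 4.2-fold lower number from compound 1 to compound 2 (0.62 log units; beyond the scatter) and a 2.8-fold lower number from compound 1 to compound 3 (0.45 log units; beyond the scatter) are beyond the scatter, whereas a 1.5-fold higher number from compound 2 to compound 3 (0.18 log units; within the scatter) is within it, so compound 2 and compound 3 cannot be set in order against each other.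

Compound 4 `O=c1c(CSC(=S)N2CCCC2)coc2ccccc12` is the next to be measured. Relative to compound 2 the change is hydrogen in place of methyl on an aromatic carbon. Going by the values given here, every measured step in this set varies the ring on the thiocarbonyl carbon; none touches the aromatic ring, so there is no direct precedent for this change. The expectation is therefore a step of a 1.3-fold higher number from compound 2 to compound 4 (0.12 log units; within the scatter) that is small, of uncertain direction and likely within the scatter, with wide uncertainty. Compound 4 is estimated at 4500 nM in this assay, with a range from 1700 nM to 12000 nM.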

Compound 4, half-maximal inhibitory concentration: 6000 nM
Beside the measured number, compound 4's estimate is 1.3-fold (0.12 log units) below it; the range from low to high includes it.
By their numbers in this assay, from the lowest: compounds 2, 3 and 4 (each within the scatter of the next); then compound 1.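

Going by these compounds alone, this is the first step made on the aromatic ring rather than on the thiocarbonyl carbon. In this assay, hydrogen in place of methyl on an aromatic carbon gives a 1.8-fold higher number from compound 2 to compound 4 (0.25 log units; within the scatter), so with the pyrrolidin-1-yl group held fixed, the read-out does not separate the methyl compound from the unsubstituted one, and the methyl is not shown to be needed for activity at this position. No independent data bear on what lies behind this step.

Only methyl and hydrogen are shown at this position, so a methoxy group, a chlorine atom or a carboxylic acid there could behave differently. On these data alone, whether the same replacement would also stay within the scatter with the morpholin-4-yl or piperidin-1-yl groups remains open.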